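Fluoro on Two Rings of a Benzothiazolyl Pyrazole Carboxamide Series

The source may hold more compounds than are shown below. What is called first, only, known or untested is meant among the compounds shown, and "the series" means these compounds.

Measured compounds:
compound 1, `COc1ccc2nc(NC(=O)c3cn(-c4ccccc4)nc3-c3ccccc3)sc2c1`, > 50000 nM
compound 2, `COc1ccc2nc(NC(=O)c3cn(-c4ccccc4)nc3-c3ccc(F)cc3)sc2c1`, > 50000 nM
compound 3, `O=C(Nc1nc2ccccc2s1)c1cn(-c2ccccc2)nc1-c1ccc(Cl)cc1`, 39600 nM

Three compounds were tested in an ADME assay on HEK-293T cells (Homo sapiens) for cytotoxicity, read by MTT assay, with a stated time of 72 h; on this read-out higher numbers stand for weaker inhibition and lower numbers for stronger inhibition. In this assay compound 1 gives > 50000 nM, which is a limit of the assay and not a number. In this assay compound 2 gives > 50000 nM, again a limit of the assay. Going by the values given here, compound 3 gives 39600 nM in this assay, the only number among the three values.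

Compound 2 differs from compound 1 by fluoro in place of hydrogen on an aromatic carbon. The step that the two limits leave unreadable from compound 1 to compound 2 cannot be read, since both values sit at the limit described by the limit of > 50000 nM in this assay, at which 2 of the 3 values shown sit. The difference between the core of compound 1 and the core of compound 3 is not broken down here.

Compound 4, `O=C(Nc1nc2ccc(F)cc2s1)c1cn(-c2ccccc2)nc1-c1ccc(Cl)cc1`, has not yet been measured in this assay. It differs from compound 3 by fluoro in place of hydrogen on an aromatic carbon. Among the compounds with values here, this is the same kind of change as the one from compound 1 to compound 2, but the place is not the same: in compound 2 the fluorine stands para to a large group on a plain six-membered ring of carbon only, while in compound 4 it stands on a ring that is part of a fused system of two rings, meta to a fused ring and para to a fused ring. Within the data shown here, the step from compound 1 to compound 2 gives no readable size, so no measured step of this change is available.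

Compound 4 is therefore expected to stay close to compound 3, with an estimated step of a 1.1-fold higher number from compound 3 to compound 4 (0.03 log units; within the scatter), resting on the value of compound 3, 39600 nM. The values of compound 1 and compound 2 are limits of the assay and add nothing further to this expectation. The estimate for compound 4 in this assay is 42000 nM, expected to lie between 15000 nM and 50000 nM.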

Compound 4, half-maximal inhibitory concentration: > 50000 nM
Compound 4 was reported as a limit; the forecaster's own chance of this, stated with the estimate: 50%; at least 1.1-fold (0.07 log units) between middle value and limit.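

In this assay, fluoro in place of hydrogen on the core of compound 3 gives an at least 1.2-fold higher number from compound 3 to compound 4 (0.10 log units; that floor lies within the scatter), and as that floor lies within the usual scatter, the result fixes no size for the change and does not by itself set compound 4 apart from compound 3. In this assay compound 4 gives > 50000 nM, which is a limit of the assay and not a number. The same kind of change on the core of compound 1 cannot be read, and it stands at a different place, so the two cores offer no pair of sizes to compare: the series shows only that compound 2 and compound 4, each carrying the added fluoro, end at one shared limit, and it does not show that the change carries over from one core to the other with the same effect: the limit of > 50000 nM in this assay, at which 3 of the 4 values shown sit.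

The compounds shown leave open how large the step from hydrogen to fluoro really is on either core, and whether fluoro at another place on these rings would give a readable number in this assay. Also open, going by these compounds, is what would follow in this assay if an amine or a carboxylic acid stood in the place taken by fluoro in 6-fluoro-1,3-benzothiazol-2-yl.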